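Chloro in place of fluoro on compound 3

This account rests on a few compounds, and the source may have more. Where it says the series, first, only, none or still open, it means among the compounds named here.

Measured in an ADME assay on Vero cells (Chlorocebus sabaeus) for cytotoxicity, read by resazurin assay, with a stated time of 72 h; a lower number here means a stronger inhibitor, a higher number a weaker inhibitor
compound 1 `O=C(CCN1CCN(c2ccc(F)cc2)CC1)c1ccccc1` gives 13400 nM
compound 2 `COc1ccc(C(=O)CCN2CCN(c3ccc(F)cc3)CC2)cc1` gives 55000 nM
compound 3 `O=C(CCN1CCN(c2ccc(F)cc2)CC1)c1ccc(F)c(F)c1` gives 385000 nM

Compound 3 has the highest number of the three, reached by a 7.0-fold higher number from compound 2 to compound 3 (0.85 log units; beyond the scatter) and by a 29-fold higher number from compound 1 to compound 3 (1.46 log units; beyond the scatter), the first modest and the second large. The next structure is compound 4 `O=C(CCN1CCN(c2ccc(F)cc2)CC1)c1ccc(F)c(Cl)c1`, and the change is chloro in place of fluoro on an aromatic carbon, so that 3,4-difluorophenyl becomes 3-chloro-4-fluorophenyl. Within the data shown here, no measured step exchanges one halogen for another, so the evidence is indirect. The two steps above do show that changing this aryl group can move the number well beyond the scatter. Compound 3 alone, at 385000 nM in this series, carries the 3,4-difluorophenyl group, and that group is lost here, so a modest step to a lower number is expected. The expected change is a 3.2-fold lower number from compound 3 to compound 4 (0.51 log units; beyond the scatter) in this assay, with wide uncertainty. For compound 4 the estimated value is 120000 nM with an expected range from 30000 nM to 400000 nM.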

Compound 4, half-maximal inhibitory concentration: 185000 nM
Estimate against measurement, compound 4: 1.5-fold (0.19 log units) below; measured number inside the range.
By their numbers in this assay, from the lowest: compound 1; then compound 2; then compound 4; then compound 3.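

In this assay, among these compounds, the step of a 2.1-fold lower number from compound 3 to compound 4 (0.32 log units; beyond the scatter) is the first direct exchange of one halogen for another, and it shows that chloro in place of fluoro, ortho to a fluoro group, moves the number beyond the scatter with the rest of the structure unchanged. The 3-chloro-4-fluorophenyl group still gives a higher number than either earlier non-halogenated aryl group, with a 3.4-fold higher number from compound 2 to compound 4 (0.53 log units; beyond the scatter) and a 14-fold higher number from compound 1 to compound 4 (1.14 log units; beyond the scatter) so the exchange removes only part of the rise seen with 3,4-difluorophenyl. Nothing measured here explains this shift.

Open, on these data alone, is whether a bromo or nitrile group at this position would extend the same trend. Also open, as far as these compounds go, is whether chloro gives a similar step without the neighbouring fluoro group present.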